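The source may report more compounds than this note shows. Statements on the series, on what has been measured and on what is new or still open speak of the compounds shown alone.

Measured so far:
compound 1, `Cc1cc(Cl)c(S(C)(=O)=O)cc1C(=O)N=C(N)N` — 25 nM in a functional assay for inhibition of sodium/hydrogen exchanger (Oryctolagus cuniculus); on this read-out lower numbers stand for stronger inhibition and higher numbers for weaker inhibition
compound 2, `Cc1cc(OCc2ccccc2)c(S(C)(=O)=O)cc1C(=O)N=C(N)N` — 28 nM in this assay

Within this pair compound 2 carries the highest of the two numbers, yet its nearest neighbour is compound 1, and the difference between them lies within the scatter, so no order between compound 1 and compound 2 can be read from these values.

Compound 3, `Cc1cc(O)c(S(C)(=O)=O)cc1C(=O)N=C(N)N`, is not yet measured. It differs from compound 2 by hydrogen in place of benzyl on an oxygen on an aromatic ring; cut one bond further out, the change reads benzyloxy to hydroxy.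

Within the data shown here, the one measured step that touches the same position is a 1.1-fold higher number from compound 1 to compound 2 (0.05 log units; within the scatter), in which chloro gave way to benzyloxy with no shift beyond the scatter. That step says nothing directly about a hydroxy group, but it shows that two very different groups at this position return near-identical numbers. A further change there to hydroxy is therefore expected to produce at most a modest step in this assay, with the direction uncertain and a slight lean toward a weaker number being as plausible as none.

Compound 3 is expected to give about 40 nM, with a range from 15 nM to 120 nM. This estimate corresponds to a step of a 1.4-fold higher number from compound 2 to compound 3 (0.15 log units; within the scatter), judged against the uninformative size of the step from chloro to benzyloxy.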

Compound 3, half-maximal inhibitory concentration: 220 nM
Estimate against measurement, compound 3: 5.5-fold (0.74 log units) below; the whole stated range lies below it.
By their numbers in this assay, from the lowest: compounds 1 and 2 (each within the scatter of the next); then compound 3.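

In this assay, the position that held chloro and benzyloxy with no shift beyond the scatter does respond to its substituent: hydrogen in place of benzyl on the oxygen gives a clear loss (a 7.9-fold higher number from compound 2 to compound 3 (0.90 log units; beyond the scatter)), and hydroxy in place of chloro gives one of similar standing (an 8.8-fold higher number from compound 1 to compound 3 (0.94 log units; beyond the scatter)). The flat pair of compound 1 and compound 2 therefore did not mean that this position accepts any group, since among the three groups shown hydroxy alone stands apart, and both steps to it run toward a higher number. No measurement on hand speaks to the reason for this separation.

As far as these compounds go, whether the shift belongs to the free hydroxy itself or would also appear with other groups remains open: methoxy on the same oxygen, or an amine in place of the hydroxy, would help to tell these readings apart. Also open, from the compounds shown here alone, is whether a longer chain on the oxygen, or a carboxylic acid at this place, returns to the level of compound 1 and compound 2.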